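The compounds below may be only part of what the source reports. "The series", "measured", "known", "first", "only" and "open" are said of these compounds alone.

Three measured compounds share one core. Compound 1 `C=CC(=O)N1CC[C@H](N2C(=O)N(c3ccccc3)Cc3cnc(Nc4cccc(N5CCN(C)CC5)c4)nc32)C1` gives, in a physicochemical assay for solubility, read by HPLC, in phosphate buffer, measured as thermodynamic solubility, with a stated time of 24 h, at pH 6.8 (on this read-out higher numbers stand for higher solubility and lower numbers for lower solubility), 714 ug/mL. Compound 2 `C=CC(=O)N1CC[C@H](N2C(=O)N(c3ccccc3)Cc3cnc(Nc4ccc(N5CCN(C)CC5)cc4)nc32)C1` gives in this assay 976 ug/mL, and compound 3 `C=CC(=O)N1CC[C@H](N2C(=O)N(c3ccccc3)Cc3cnc(Nc4ccc(N5CCN(C)CC5)c(C)c4)nc32)C1` gives 1270 ug/mL. Compound 2 stands second highest of the three numbers; its nearest neighbour is compound 3 and its furthest is compound 1, and both of those gaps are within the scatter, so no order among the three can be claimed. Going by the values given here, the one measured single-point step, a 1.3-fold higher number from compound 2 to compound 3 (0.11 log units; within the scatter), concerns a methyl in place of hydrogen on an aromatic carbon and stays within the scatter.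

Compound 4 `C=CC(=O)N1CC[C@H](N2C(=O)N(c3ccccc3)Cc3cnc(Nc4ccccc4)nc32)C1` differs from compound 2 by hydrogen in place of 4-methylpiperazin-1-yl on an aromatic carbon. Among the compounds with values here, no measured step touches the 4-methylpiperazin-1-yl group: all three measured compounds carry it, and the only measured step moves a single methyl. The estimate therefore rests on the size of the change alone, which removes a group of 7 heavy atoms with 2 hydrogen-bond acceptors. Compound 4 is expected to give a lower number in this assay, by a step beyond the scatter, a 33-fold lower number from compound 2 to compound 4 (1.51 log units; beyond the scatter). The estimate for compound 4 is 30 ug/mL, between 5 ug/mL and 200 ug/mL.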

Compound 4, solubility: 3.5 ug/mL
Estimate against measurement, compound 4: 8.6-fold (0.93 log units) above; measured number outside the range, below it.
By their numbers in this assay, from the lowest: compound 4; then compounds 1, 2 and 3 (each within the scatter of the next).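

Going by these compounds alone, exchanging the 4-methylpiperazin-1-yl group for hydrogen is the one change that moves the number in this assay beyond the scatter, giving a 280-fold lower number from compound 2 to compound 4 (2.45 log units; beyond the scatter) and, read from the other compound that carries the group, a 200-fold lower number from compound 1 to compound 4 (2.31 log units; beyond the scatter). Within the data shown here, the earlier compounds, all of which keep the group, showed only a methyl step within the scatter, whereas the large gap now separates compound 4, the one compound without the group, from compounds 1, 2 and 3, which stand within the scatter of one another. Nothing shown here bears on what lies behind this gap.

The compounds shown span only the two extremes of the full 4-methylpiperazin-1-yl group and bare hydrogen, so it stays open whether a piperazine without its methyl, a morpholine ring or a simple dimethylamino group would keep the number close to that of compound 2 at 976 ug/mL. From the compounds shown here alone, it also stays open how a carboxylic acid on the same aromatic carbon would read, and whether a step of this size would recur on a different core.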